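Thiosemicarbazide and thiosemicarbazone analogues: growth inhibition notes

The source may hold more compounds than are shown below. What is called first, only, known or untested is meant among the compounds shown, and "the series" means these compounds.

Compound 1 `CC1=CC[C@@H]([C@@](C)(O)CCCC(C)(C)NC=S)CC1` gives 16000 nM in a functional assay on MCF7 cells (Homo sapiens) for cytotoxicity, read by sulforhodamine B assay; a higher number here means a weaker inhibitor of growth, a lower number a stronger inhibitor of growth.
Compound 2 `CC1=CC[C@@H]([C@@](C)(O)CCCC(C)(C)NC(=S)N/N=C\c2ccccc2[N+](=O)[O-])CC1` gives 18600 nM in this assay.

Compound 2 holds the higher of the two numbers, but its gap to compound 1 lies within the usual scatter, so the two measured compounds cannot be told apart on growth inhibition. Both sit in a weak range.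

Compound 3 `CC1=CC[C@@H]([C@@](C)(O)CCCC(C)(C)NC(=S)N/N=C\c2ccc(Cl)cc2)CC1` awaits measurement. It differs from compound 2 in one place: 4-chlorophenyl in place of 2-nitrophenyl on a carbon with a double bond to nitrogen. For the measured compounds named here, no step between measured compounds speaks to this kind of change, and the two measured values give no direction to build on. The step of a 1.2-fold lower number from compound 2 to compound 3 (0.09 log units; within the scatter) is therefore expected to stay within the scatter, with no clear direction. Compound 3 is estimated at 15000 nM in this assay, with a range from 6000 nM to 40000 nM.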

Compound 3, concentration for 50% growth inhibition: 6890 nM
Estimate against measurement, compound 3: 2.2-fold (0.34 log units) above; measured number inside the range.
By their numbers in this assay, from the lowest: compound 3; then compounds 1 and 2 (each within the scatter of the next).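

For the compounds shown here, at the aryl group on the carbon with a double bond to nitrogen, the choice of group does register in this assay: 4-chlorophenyl in place of 2-nitrophenyl gives a 2.7-fold lower number from compound 2 to compound 3 (0.43 log units; beyond the scatter) and is the first step to lie beyond the scatter, though it remains modest. The series therefore has at least one place where growth inhibition responds to a change, which the two earlier values could not show. No measurement on hand offers an explanation for this step.

This single step cannot separate the gain of 4-chlorophenyl from the loss of 2-nitrophenyl, so the contribution of each group remains unresolved. Open too, on these data alone, is how unsubstituted phenyl, 2-chlorophenyl, 4-nitrophenyl or an aryl group carrying an amine or a carboxylic acid would stand at this place.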